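Ring Swap on the Thioether Side Chain

The source may hold more compounds than are shown below. What is called first, only, known or untested is meant among the compounds shown, and "the series" means these compounds.

Measured compounds:
compound 1, `CC1=CC(=O)OC(CSc2nc(-c3ccccc3)c(-c3ccccc3)[nH]2)C1` — 200 nM
compound 2, `CC1(C)CC(=O)OC(CSc2nc(-c3ccccc3)c(-c3ccccc3)[nH]2)C1` — 100 nM
compound 3, `c1ccc(-c2nc(SCC3CCCCO3)[nH]c2-c2ccccc2)cc1` — 210 nM

All three compounds share a core that differs only in the ring carried on the saturated chain carbon bound to a sulfur. In an assay on microsomes from liver for inhibition of sterol O-acyltransferase 1 (Rattus norvegicus) (a higher number here means a weaker inhibitor, a lower number a stronger inhibitor), compound 3 gives the highest number of the three. Its separation from compound 1 is small, a 1.1-fold higher number from compound 1 to compound 3 (0.02 log units; within the scatter), and lies within the scatter; its separation from compound 2 is a 2.1-fold higher number from compound 2 to compound 3 (0.32 log units; beyond the scatter), a modest step beyond the scatter. The step of a 2.0-fold lower number from compound 1 to compound 2 (0.30 log units; within the scatter) is itself within the scatter.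

Compound 4, `c1ccc(-c2nc(SCC3OCCO3)[nH]c2-c2ccccc2)cc1`, has not yet been measured. It differs from compound 3 by 1,3-dioxolan-2-yl in place of oxan-2-yl on a saturated chain carbon bound to a sulfur. Every measured step in this series exchanges one ring for another at exactly this place, and none of them moved the number by more than a modest amount. Among the compounds with values here, on that basis the change from compound 3 to compound 4 is expected to produce no step clearly beyond the scatter in this assay, in either direction.

Compound 4 is therefore expected to give 250 nM in this assay, with a likely range from 100 nM to 600 nM. This estimate corresponds to an expected 1.2-fold higher number from compound 3 to compound 4 (0.08 log units; within the scatter).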

Compound 4, half-maximal inhibitory concentration: 530 nM
For compound 4 the middle estimate is 2.1-fold (0.33 log units) below the measured one; the measured number falls inside the stated range.
By their numbers in this assay, from the lowest: compounds 2, 1 and 3 (each within the scatter of the next, the first and the last beyond it); then compound 4.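

In this assay, 1,3-dioxolan-2-yl, the only five-membered ring among these compounds, gives the highest number of the four, with a 2.5-fold higher number from compound 3 to compound 4 (0.40 log units; beyond the scatter), a 2.7-fold higher number from compound 1 to compound 4 (0.42 log units; beyond the scatter) and a 5.3-fold higher number from compound 2 to compound 4 (0.72 log units; beyond the scatter), which makes compound 4 the weakest inhibitor shown. Within the data shown here, the ring on the saturated chain carbon bound to a sulfur therefore matters more than the earlier compounds suggested: among the six-membered rings, only the step from compound 2 to compound 3 passed the scatter, and only modestly, whereas every step to compound 4 passes it. The exchange of oxan-2-yl for 1,3-dioxolan-2-yl alters ring size and the count of ring hetero atoms together, and no measurement at hand explains the rise.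

The compounds shown leave open which of those two changes matters, a question that oxolan-2-yl and 1,3-dioxan-2-yl could help to separate. Also open, from the compounds shown here alone, is how this position would respond to an amine such as piperidin-2-yl, or to an open chain such as 2-methoxyethyl in place of a ring.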